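This account rests on a few compounds, and the source may have more. Where it says the series, first, only, none or still open, it means among the compounds named here.

Compound 1 `COc1cc(-c2cccc3nc(-c4ccccc4)oc23)cc(OC)c1OC`: > 25000 nM, a limit
Compound 2 `COc1cccc(-c2nc3cccc(-c4cc(OC)c(OC)c(OC)c4)c3o2)c1`: > 25000 nM, a limit
Compound 3 `COc1ccc(-c2nc3cccc(-c4cc(OC)c(OC)c(OC)c4)c3o2)cc1F`: > 25000 nM, a limit

All three results come from a functional assay on MCF7 cells (Homo sapiens) for antiproliferative activity, read by MTT assay, with a stated time of 48 h (on this read-out lower numbers stand for stronger inhibition and higher numbers for weaker inhibition), and none of them is an actual number. The whole set sits at one ceiling, (the limit of > 25000 nM in this assay, at which 3 of the 3 values shown sit). Compound 2 therefore has no number of its own, only the limit > 25000 nM.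

The next compound to be measured is compound 4 `COc1cc(-c2cccc3nc(-c4ccc(F)cc4)oc23)cc(OC)c1OC`. It keeps the core of compound 2 and carries 4-fluorophenyl in place of 3-methoxyphenyl on an aromatic carbon.

Going by the values given here, three measured steps bear on this change, each made in the same part of the molecule: a step that the two limits leave unreadable from compound 1 to compound 2, a step that the two limits leave unreadable from compound 1 to compound 3 and a step that the two limits leave unreadable from compound 2 to compound 3. None has a readable size, so they offer no direction. Phenyl, 3-methoxyphenyl and 3-fluoro-4-methoxyphenyl have all given only the limit, so no group tried here has yet produced a number in this assay.

No step beyond the usual scatter is therefore expected, and the estimated step is a step that the limit leaves unreadable from compound 2 to compound 4. Compound 4 will most likely be reported as a limit as well. For compound 4 the estimated value is 30000 nM, with an expected range from 10000 nM to 60000 nM.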

Compound 4, half-maximal inhibitory concentration: > 25000 nM
Compound 4: no number, only a limit (the forecaster's own chance of this, stated with the estimate: 80%); the middle value does not contradict the limit.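

In this assay compound 4 gives > 25000 nM, which is a limit and not a number. Its steps from compound 1, compound 2 and compound 3 therefore cannot be read, and the set stays at one ceiling: the limit of > 25000 nM in this assay, at which 4 of the 4 values shown sit.

The compounds shown leave open whether any group at this place on the shared core would give an actual number.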